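Butoxy to isobutoxy at the assay limit

The source may report more compounds than this note shows. Statements on the series, on what has been measured and on what is new or still open speak of the compounds shown alone.

In a functional assay on NCI-H23 cells (Homo sapiens) for antiproliferative activity, read by sulforhodamine B assay (on this read-out higher numbers stand for weaker inhibition of growth and lower numbers for stronger inhibition of growth), compound 3 `CCCCOc1cccc(O)c1C(=O)/C=C/c1ccc(O)cc1` reads > 30000 nM and this is a limit of the assay, not a number. Compound 1 `O=C(/C=C/c1ccc(O)cc1)c1c(O)cccc1OCCC1CCCCC1` reads > 30000 nM and this is likewise a limit. Compound 2 `O=C(/C=C/c1ccc(O)cc1)c1c(O)cccc1OCC1CCCCC1` reads > 30000 nM and this too is a limit. Within the data shown here, the whole series so far is summed up by the limit of > 30000 nM in this assay, at which 3 of the 3 values shown sit, and compound 3 therefore offers no firm number to start from.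

Compound 4 `CC(C)COc1cccc(O)c1C(=O)/C=C/c1ccc(O)cc1` keeps the shared core and alters only the chain: isopropyl in place of propyl on a saturated chain carbon bound to an oxygen on an aromatic ring and so isopropyl stands in place of propyl on a saturated chain carbon bound to an oxygen on an aromatic ring. Butoxy thus becomes isobutoxy.

Among the measured compounds shown here, three measured steps bear on this: a step that the two limits leave unreadable from compound 2 to compound 3 and a step that the two limits leave unreadable from compound 1 to compound 3 and a step that the two limits leave unreadable from compound 1 to compound 2 are all changes in the same chain. The limits leave the size of each one unreadable, and none of these changes brought a compound out of the limit.

The estimated step of a number no higher from compound 3 to compound 4 (the limit leaves the size open) is therefore expected to stay within the scatter, with no direction foreseen. Compound 4 is expected at 30000 nM with an estimated range from 12000 nM to 60000 nM and the assay may well report only a limit again.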

Compound 4, concentration for 50% growth inhibition: 3220 nM
For compound 4 the middle estimate is 9.3-fold (0.97 log units) above the measured one; the whole stated range lies above it.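

In this assay, among these compounds, compound 4 is the first compound to give a firm number, and the change from butoxy to isobutoxy gives an at least 9.3-fold lower number from compound 3 to compound 4 (0.96 log units; beyond the scatter). The atoms stay the same and only the way they are joined differs, so at this saturated chain carbon bound to an oxygen on an aromatic ring, the arrangement of the chain can matter as well as its atom count; compared with the two chains that carry a cyclohexyl ring, the result is an at least 9.3-fold lower number from compound 2 to compound 4 (0.96 log units; beyond the scatter) and an at least 9.3-fold lower number from compound 1 to compound 4 (0.96 log units; beyond the scatter). The steps among the three earlier compounds cannot be read, and each of the three steps to compound 4 starts from a limit, so its true size remains unknown, with the earlier compounds all sitting at the same limit: the limit of > 30000 nM in this assay, at which 3 of the 4 values shown sit.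

Isobutoxy is the only chain shown that gives a firm number, so a single compound cannot show whether other chains would also do so, such as isopentyloxy, a longer chain, or a chain ending in an amine. The data leave open how this one rearrangement changes growth inhibition. As far as these compounds go, whether the same change would have a similar effect on other cell lines also remains open.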